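Trimming the Aryl Group of Compound 1

The source may hold more compounds than are shown below. What is called first, only, known or untested is meant among the compounds shown, and "the series" means these compounds.

Compound 1 `Cn1c(=O)c(=O)n(C2CCCC2)c2nc(N/N=C/c3ccc(O)c(F)c3)ncc21` has the highest number of the three measured compounds in a functional assay on PC-3 cells (Homo sapiens) for antiproliferative activity, read by MTT assay (on this read-out higher numbers stand for weaker inhibition and lower numbers for stronger inhibition), where compound 1 gives 85200 nM. Compound 2 `Cn1c(=O)c(=O)n(C2CCCC2)c2nc(N/N=C/c3ccc(F)cc3Cl)ncc21` gives 15200 nM, and compound 3 `COc1ccc(/C=N/Nc2ncc3c(n2)n(C2CCCC2)c(=O)c(=O)n3C)cc1` gives 26300 nM. Compound 4 `Cn1c(=O)c(=O)n(C2CCCC2)c2nc(N/N=C/c3cccc(O)c3)ncc21` differs from compound 1 in one place: 3-hydroxyphenyl in place of 3-fluoro-4-hydroxyphenyl on a carbon with a double bond to nitrogen. Among the measured compounds shown here, two measured steps bear on this, both changing the same aryl group of compound 1: a modest lowering of a 5.6-fold lower number from compound 1 to compound 2 (0.75 log units; beyond the scatter) and a modest lowering of a 3.2-fold lower number from compound 1 to compound 3 (0.51 log units; beyond the scatter). For the measured compounds named here, a modest lowering is therefore expected for compound 4 as well, with the caution that no measured step removes only the fluorine or moves the hydroxyl. Compound 4 is estimated at 40000 nM, within a range from 15000 nM to 110000 nM, which means an expected step of a 2.1-fold lower number from compound 1 to compound 4 (0.33 log units; beyond the scatter).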

Compound 4, half-maximal inhibitory concentration: 36300 nM
Compound 4: the middle estimate sits 1.1-fold (0.04 log units) above what was measured, within the range that was stated.
By their numbers in this assay, from the lowest: compounds 2, 3 and 4 (each within the scatter of the next, the first and the last beyond it); then compound 1.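

Replacing 3-fluoro-4-hydroxyphenyl with 3-hydroxyphenyl gives a 2.3-fold lower number from compound 1 to compound 4 (0.37 log units; beyond the scatter), so an aryl group at this place can keep a hydroxyl and still lose part of the high number of compound 1. The step to the 4-methoxyphenyl group, a 1.4-fold higher number from compound 3 to compound 4 (0.14 log units; within the scatter), stays within the scatter, while the step from the 2-chloro-4-fluorophenyl group, a 2.4-fold higher number from compound 2 to compound 4 (0.38 log units; beyond the scatter), lies beyond it. No measurement here explains these steps. The loss of the fluorine and the new place of the hydroxyl remain unseparated. As far as these compounds go, how an amine or a carboxylic acid on this aryl ring would read also remains open.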